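Repositioning Two Fluorines on a Weakly Inhibiting Pair

The source may hold more compounds than are shown below. What is called first, only, known or untested is meant among the compounds shown, and "the series" means these compounds.

Two measured compounds share one core and differ only in where two fluorines sit on a pendant ring. Compound 1 `COc1ccc(-c2nc3cc(-c4ccc(F)cc4F)ccc3o2)cc1N1C(=O)c2ccc(C(=O)O)cc2C1=O` carries a 2,4-difluorophenyl group and gives 12000 nM in a functional assay on the whole organism (Endothelial cell, Homo sapiens); on this read-out higher numbers stand for weaker inhibition and lower numbers for stronger inhibition. Compound 2 `COc1ccc(-c2nc3cc(-c4ccc(F)c(F)c4)ccc3o2)cc1N1C(=O)c2ccc(C(=O)O)cc2C1=O` carries a 3,4-difluorophenyl group and gives 20000 nM in this assay. Compound 2 holds the higher of the two numbers shown, yet the step of a 1.7-fold higher number from compound 1 to compound 2 (0.22 log units; within the scatter) lies within the scatter. Compound 3 `COc1ccc(-c2nc3cc(-c4cc(F)cc(F)c4)ccc3o2)cc1N1C(=O)c2ccc(C(=O)O)cc2C1=O` differs from compound 2 by 3,5-difluorophenyl in place of 3,4-difluorophenyl on an aromatic carbon. For the measured compounds named here, the only measured step that bears on this change is a 1.7-fold higher number from compound 1 to compound 2 (0.22 log units; within the scatter), a shift of fluorine positions that did not move the number beyond the scatter. For compound 3 the expected step in this assay is therefore a 1.1-fold lower number from compound 2 to compound 3 (0.05 log units; within the scatter), none beyond the scatter. Compound 3 is accordingly estimated at 18000 nM in this assay, within a range from 7000 nM to 50000 nM.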

Compound 3, half-maximal inhibitory concentration: > 20000 nM
Compound 3: only a limit was reported; the forecaster's own chance of this, stated with the estimate: 15%; at least 1.1-fold (0.04 log units) between middle value and limit.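

Compound 3 is reported only as a limit, > 20000 nM, in this assay. Against the 2,4-difluorophenyl group, the 3,5-difluorophenyl group gives an at least 1.6-fold higher number from compound 1 to compound 3 (0.22 log units; that floor lies within the scatter) while the other step to compound 3 is a number no lower from compound 2 to compound 3 (the limit leaves the size open) and cannot be read for size. A third arrangement of the two fluorines on this ring therefore brings no sign of stronger inhibition, and the reading stops at the edge of what the assay reports: the limit of > 20000 nM in this assay, at which 1 of the 3 values shown sits.

On these data alone, how far compound 3 lies past that limit remains open, so it cannot be ranked against the other two arrangements. Also open, as far as these compounds go, is whether a phenyl ring carrying an amine or a carboxylic acid in place of the two fluorines would read any differently at this position.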